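Ethoxy at the carbamate-bearing chain carbon of compound 3

A few compounds are considered here, and "the series" means these few. Any claim that something is new, unique, unknown or untested is made for them only; others in the source may bear on it.

Compound 3, `CCC1=C(N2CC2)C(=O)C(CCOC(N)=O)=C(N2CC2)C1=O`, gives 5.48 in a functional assay on L1210 cells (Mus musculus), with a stated time of 12 days; a higher number here means a more potent compound, by a factor of ten per unit of this negative logarithm, a lower number a less potent compound. Compound 1, `CCOC(COC(N)=O)C1=C(N2CC2)C(=O)C(C)=C(N2CC2)C1=O`, gives 5.22, and compound 2, `CCC1=C(N2CC2)C(=O)C(C(COC(N)=O)OC)=C(N2CC2)C1=O`, gives 5.22; the three numbers lie within the scatter of one another, so none of them is set apart.

Compound 4, `CCOC(COC(N)=O)C1=C(N2CC2)C(=O)C(CC)=C(N2CC2)C1=O`, is not yet measured. It differs from compound 3 by ethoxy in place of hydrogen on a saturated chain carbon bound to a double-bonded ring carbon and a saturated chain carbon. Among the compounds with values here, the one measured step that touches this position is a number 0.26 log units higher from compound 2 to compound 3 (within the scatter), where the alkoxy group left and hydrogen came in, and the number stayed within the scatter. Compound 4 goes the other way, putting an alkoxy group back at that carbon, and its closest measured relative with an alkoxy group there, compound 1, stands at 5.22, the same number as compound 2 at 5.22.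

On these grounds the expected step is a number 0.23 log units lower from compound 3 to compound 4 (within the scatter), a small downward move that stays within the scatter, and compound 4 is expected to give about 5.25 in this assay, with a range from 4.85 to 5.65. The estimate is anchored on compound 1 because its value of 5.22 belongs to the nearest alkoxy-bearing analogue.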

Compound 4, logarithm of the reciprocal of the active concentration, log(1/C): 5.24
Beside the measured number, compound 4's estimate is 0.01 log units above it; measured number inside the range.
By their numbers in this assay, from the lowest: compounds 1, 2, 4 and 3 (each within the scatter of the next).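

In this assay, ethoxy in place of hydrogen on a saturated chain carbon bound to a double-bonded ring carbon and a saturated chain carbon gives a number 0.24 log units lower from compound 3 to compound 4 (within the scatter), so this position now has a direct ethoxy-to-hydrogen comparison on the core of compound 3, alongside the methoxy comparison, a number 0.26 log units higher from compound 2 to compound 3 (within the scatter). Two further single changes also stay within the scatter: methyl in place of hydrogen on a saturated chain carbon bound to an oxygen on a saturated carbon, which turns methoxy into ethoxy, gives a number 0.02 log units higher from compound 2 to compound 4 (within the scatter), and methyl in place of hydrogen on a saturated chain carbon bound to a double-bonded ring carbon gives a number 0.02 log units higher from compound 1 to compound 4 (within the scatter). Across these four compounds, neither the presence of an alkoxy group at this position nor its length sets any compound apart, and nothing at hand bears on the reason for these small differences.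

As far as these compounds go, whether an amine, a carboxylic acid or a longer chain such as butoxy at the same carbon would stay within the scatter remains open. The compounds shown also leave open what happens when the carbamate is replaced by a hydroxyl group or an amide.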